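The compounds below may be only part of what the source reports. "The series", "measured", "known", "first", "only" and "open" are said of these compounds alone.

Measured compounds:
compound 1 `COc1cc(Cl)cc(-c2nn(-c3cccc(NC(=O)c4ccc(Cl)c(Cl)c4)c3)cc2-c2ccncc2)c1` — 53.7%
compound 2 `COc1cc(Cl)cc(-c2nn(-c3cccc(NC(=O)Nc4ccc(Cl)c(C(F)(F)F)c4)c3)cc2-c2ccncc2)c1` — -10.4%
compound 3 `COc1cc(Cl)cc(-c2nn(-c3cccc(NC(=O)Nc4cccc(C(F)(F)F)c4)c3)cc2-c2ccncc2)c1` — -18.6%

In a functional assay on NCI-H522 cells (Homo sapiens) for inhibition, read by sulforhodamine B assay, with a stated time of 48 h, tested at 10 uM (on this read-out higher numbers stand for a weaker effect at the one concentration tested and lower numbers for a stronger effect), compound 3 sits at the low end of the three numbers; compound 2 lies within the usual scatter of it (a number 8.2 percentage points lower from compound 2 to compound 3 (within the scatter)), while compound 1 stands well apart (a number 72.3 percentage points lower from compound 1 to compound 3 (beyond the scatter)).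

Compound 4 `COc1cc(Cl)cc(-c2nn(-c3cccc(NC(=O)c4cccc(C(F)(F)F)c4)c3)cc2-c2ccncc2)c1` is not yet measured. It differs from compound 3 in one place: 3-(trifluoromethyl)phenyl in place of (3-(trifluoromethyl)phenyl)amino on a carbonyl carbon.

Among the compounds with values here, no measured step isolates this change. The nearest comparisons are the two that run from compound 1 to the two compounds with the amide-type nitrogen on the carbonyl carbon: a number 64.1 percentage points lower from compound 1 to compound 2 (beyond the scatter) and a number 72.3 percentage points lower from compound 1 to compound 3 (beyond the scatter). Both were large and in the same direction, though each also carried a change of the substituents on the aromatic ring. The step from compound 3 to compound 4 reverses the direction of those two, so a large rise in this assay is expected, back toward the region of compound 1. The step is estimated as a number 58.6 percentage points higher from compound 3 to compound 4 (beyond the scatter).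

For compound 4 the expected value is 40%, with a range from 0% to 75%.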

Compound 4, a percentage reported as activity, at one concentration (the size of the read-out at that concentration, not a potency): 32.2%
Compound 4: middle estimate off by 7.8 percentage points, on the high side; low and high end bracket the measured number.
By their numbers in this assay, from the lowest: compounds 3 and 2 (each within the scatter of the next); then compound 4; then compound 1.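

Within the data shown here, with the aryl group held as 3-(trifluoromethyl)phenyl, removing the amino nitrogen from the carbonyl carbon gives, in this assay, a number 50.8 percentage points higher from compound 3 to compound 4 (beyond the scatter), the first reading of this change without a second change in the same pair. The step of a number 42.6 percentage points higher from compound 2 to compound 4 (beyond the scatter) is of similar size but also includes loss of the chloro group, whereas among the compounds without that nitrogen the aryl change alone gives the modest step of a number 21.5 percentage points lower from compound 1 to compound 4 (beyond the scatter), so the aryl group also matters at this position, though by less than the nitrogen. No measured evidence bearing on the origin of these differences is available.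

Going by these compounds, the effect of a methylene group or an oxygen atom in place of the amino nitrogen on the carbonyl carbon remains open. Also open, on these data alone, is whether the same rise holds with a 3,4-dichlorophenyl group on the amino nitrogen.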